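Permeability notes on the shared-core series, compound 2 to compound 4

The compounds below may be only part of what the source reports. "The series", "measured", "known", "first", "only" and "open" are said of these compounds alone.

Measured so far in an ADME assay on Caco-2 cells (Homo sapiens) for permeability, in the apical to basolateral direction; on this read-out lower numbers stand for lower permeability and higher numbers for higher permeability:
- compound 1 `Cc1c(NC(=O)c2ccc(C(C)(C)C)cc2)cccc1-c1ccnc2[nH]c(-c3cnn(C)c3)nc12` gives 0.6 10^-6 cm/s
- compound 2 `Cn1cc(-c2nc3c(-c4ccc(CNC(=O)c5cc(C(C)(C)C)no5)c(F)c4)ccnc3[nH]2)cn1` gives 3 10^-6 cm/s
- compound 3 `Cn1cc(-c2nc3c(-c4ccc(CN5CCc6cc(C(C)(C)C)ccc6C5=O)c(F)c4)ccnc3[nH]2)cn1` gives 0.2 10^-6 cm/s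

Compound 2 stands highest of the three numbers. Its nearest neighbour is compound 1, whose number is lower by a margin beyond the usual scatter; compound 3 lies further away still, also beyond the scatter. Among the compounds with values here, none of these three pairs differs in only one place, so no single step between measured compounds can be read off.

Compound 4 `Cn1cc(-c2nc3c(-c4ccc(CNC(=O)N5CC(OC(C)(C)C)C5)c(F)c4)ccnc3[nH]2)cn1` is not yet measured in this assay. It departs from compound 2 at one place: a group of 9 heavy atoms (7 carbon, 1 nitrogen, 1 oxygen; one four-membered non-aromatic ring with 1 hetero atom) in place of a group of 9 heavy atoms (7 carbon, 1 nitrogen, 1 oxygen; one five-membered aromatic ring with 2 hetero atoms), on a carbonyl carbon. The carbonyl carbon keeps its amide-type nitrogen neighbour; what changes is the group on its other side, a five-membered aromatic ring with 2 hetero atoms giving way to a four-membered non-aromatic ring with 1 hetero atom, the heavy-atom count unchanged.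

With no measured step of this kind in the series, the expectation is a small downward move or none beyond the scatter, a 1.5-fold lower number from compound 2 to compound 4 (0.18 log units; within the scatter), resting only on the value of compound 2, 3 10^-6 cm/s, as the anchor. Compound 4 is therefore estimated at 2 10^-6 cm/s, in the range 0.7 10^-6 cm/s to 6 10^-6 cm/s.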

Compound 4, apparent permeability: 0.4 10^-6 cm/s
The estimate for compound 4 lay 5.0-fold (0.70 log units) above the measured number; the measured number lies below the stated range.
By their numbers in this assay, from the lowest: compounds 3, 4 and 1 (each within the scatter of the next, the first and the last beyond it); then compound 2.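

In this assay, within the data shown here, this is the first single-place change that can be read, and it gives a 7.5-fold lower number from compound 2 to compound 4 (0.88 log units; beyond the scatter), so the group on the carbonyl carbon is a position where the number can move beyond the scatter. The leaving 3-(tert-butyl)-1,2-oxazol-5-yl and the entering group have the same heavy-atom count and the same carbon, nitrogen and oxygen counts, with no hydrogen-bond donors and no net charge, so matching these counts did not keep the number in place; the two differ in ring size, in aromatic character and by one hydrogen-bond acceptor. No measurement at hand bears on which of these differences accounts for the step.

The compounds shown leave open whether the step goes with the loss of the aromatic ring or with the four-membered ring itself, a question that a pyrrolidine or a phenyl ring on the same carbonyl carbon would help to settle. Going by these compounds, whether the exchange gives a similar step on another scaffold also stays open: compound 1 and compound 3 each differ from compound 2 in more than one place.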